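The compounds below may be only part of what the source reports. "The series", "measured", "known", "first", "only" and "open" are said of these compounds alone.

Working notes on the series. Three compounds with a shared core have been run: compound 1 `NC(=O)Cn1c(-c2ccc(Br)cc2)nc2cccnc21`, compound 2 `CN(C)C(=O)Cn1c(-c2ccc(Br)cc2)nc2cccnc21` and compound 3 `CCN(CC)C(=O)Cn1c(-c2ccc(Cl)cc2)nc2cccnc21`; the unmeasured member is compound 4 `CN(C)CCNC(=O)Cn1c(-c2ccc(Cl)cc2)nc2cccnc21`. In a functional assay on the whole organism with Mus musculus as the target (a higher number here means that more compound is needed for the effect, a lower number that less compound is needed), compound 1 gives 17.8 mg/kg, compound 2 gives 7 mg/kg and compound 3 gives 16 mg/kg. Compound 3 thus holds the second highest of the three numbers: its value and that of compound 1 lie within the scatter of one another, while compound 2 sits beyond the scatter below it. Among the measured compounds shown here, the only step between measured compounds differing in one place is a 2.5-fold lower number from compound 1 to compound 2 (0.41 log units; beyond the scatter), a modest one.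

Compound 4 differs from compound 3 by (2-(dimethylamino)ethyl)amino in place of diethylamino on a carbonyl carbon. The measured step bears on this only loosely: it sits on the same carbonyl carbon but moves from amino to dimethylamino, whereas here diethylamino leaves, and the diethylamino of compound 3 gives a number within the scatter of compound 1. For the measured compounds named here, no measured pair shows what (2-(dimethylamino)ethyl)amino does on this carbonyl carbon. The expectation in this assay is therefore a step of a 1.3-fold lower number from compound 3 to compound 4 (0.12 log units; within the scatter), within the scatter, with no firm direction. Compound 4 is accordingly estimated at 12 mg/kg in this assay, with a range from 5 mg/kg to 30 mg/kg.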

Compound 4, dose for half-maximal effect: 62 mg/kg
Beside the measured number, compound 4's estimate is 5.2-fold (0.71 log units) below it, outside the stated range (above it).
By their numbers in this assay, from the lowest: compound 2; then compounds 3 and 1 (each within the scatter of the next); then compound 4.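

In this assay this carbonyl carbon now shows a step upward: a 3.9-fold higher number from compound 3 to compound 4 (0.59 log units; beyond the scatter) accompanies (2-(dimethylamino)ethyl)amino in place of diethylamino, the opposite direction to a 2.5-fold lower number from compound 1 to compound 2 (0.41 log units; beyond the scatter) with dimethylamino in place of amino on a carbonyl carbon. The group on this carbonyl carbon can therefore move the number beyond the scatter either way, and swapping one amine-derived group for another of similar size does not leave it unchanged: the heavy-atom count shifts only from 5 to 6, while the entering group carries a hydrogen-bond donor and a hydrogen-bond acceptor and the leaving group carries neither. Nothing at hand explains this step.

The compounds shown leave open whether the step goes with the amide hydrogen or with the terminal dimethylamino; ethylamino or (2-methoxyethyl)amino on the same carbonyl carbon would separate the two, and a longer chain such as (3-(dimethylamino)propyl)amino would test the spacing. Going by these compounds, the two steps also stand on different halogens, bromo in one pair and chloro in the other, so it remains open whether either step carries over to the other halogen.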